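A few compounds are considered here, and "the series" means these few. Any claim that something is new, unique, unknown or untested is made for them only; others in the source may bear on it.

Measured so far:
- compound 1, `OCc1ccc(CNc2cc(Br)cc3[nH]ncc23)cc1`: 45%
- compound 2, `Nc1ccc(CNc2cc(Br)cc3[nH]ncc23)cc1`: 3%
- compound 3, `ONc1ccc(CNc2cc(Br)cc3[nH]ncc23)cc1`: "not active" (no number reported)

In an assay for inhibition of Indoleamine 2,3-dioxygenase 1 (Homo sapiens), with a stated time of 1 h, tested at 10 uM (a higher number here means more inhibition at the concentration tested (going by the name of the read-out), a lower number less inhibition), compound 1 gives 45%. The step of a number 42 percentage points lower from compound 1 to compound 2 (beyond the scatter) shows that swapping hydroxymethyl for amino brings this assay down sharply. Compound 3 has no number at all in this assay; it is reported only as "not active" (no number reported), so it stands at the bottom of the three, with compound 2 nearby and compound 1 well above.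

Compound 4, `N#Cc1ccc(CNc2cc(Br)cc3[nH]ncc23)cc1`, differs from compound 3 by cyano in place of hydroxyamino on an aromatic carbon. Within the data shown here, no measured step covers a cyano group directly. Among the measured compounds shown here, the only step that bears on this position is the one from compound 1 to compound 2, which was large and downward, and compound 3 adds a second weak result for a group of two heavy atoms at this place. Compound 4 is therefore expected to stay in the weak region, with a modest rise over compound 3 possible but uncertain; its value in this assay is estimated at 15%, within 0% to 45%.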

Compound 4, a percentage reported as inhibition, at one concentration (the size of the read-out at that concentration, not a potency): 70%
Beside the measured number, compound 4's estimate is 55 percentage points below it, outside the stated range (above it).
By their numbers in this assay, from the lowest: compound 2; then compound 1; then compound 4.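

At this place on the aromatic ring, para to a large group, a change need not lower the read-out in this assay: cyano gives a number 67 percentage points higher from compound 2 to compound 4 (beyond the scatter) and a number 25 percentage points higher from compound 1 to compound 4 (beyond the scatter). Group size in heavy atoms does not settle the outcome, since hydroxyamino and cyano have the same count, yet compound 3 is reported as "not active" (no number reported) and compound 4 gives 70%, although no step between them can be read without a number for compound 3. Nothing measured here accounts for this difference.

The compounds shown leave open whether the triple bond or the lack of hydrogen-bond donors in cyano matters more. A carboxylic acid, an amide or a longer chain ending in a nitrile at this place could help separate those two features.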